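One chloro gives way to fluoro in compound 2

A few compounds are considered here, and "the series" means these few. Any claim that something is new, unique, unknown or untested is made for them only; others in the source may bear on it.

Compound 1 `O=C(CSc1nc(Cc2c(F)cccc2F)cc(=O)[nH]1)c1ccccc1` and compound 2 `O=C(CSc1nc(Cc2c(Cl)cccc2Cl)cc(=O)[nH]1)c1ccccc1` share the same core and differ only in the aryl group. In an ADME assay on MT4 cells (Homo sapiens) for cytotoxicity, read by MTT assay (on this read-out lower numbers stand for higher toxicity in this test and higher numbers for lower toxicity in this test), compound 1 gives > 67000 nM, which is a limit and not a number. In this assay compound 2 gives > 12000 nM, which is also a limit, so compound 2 has no exact place on the scale. Compound 3 `O=C(CSc1nc(Cc2c(F)cccc2Cl)cc(=O)[nH]1)c1ccccc1` follows from compound 2 by a single exchange: fluoro in place of chloro on an aromatic carbon. This puts fluoro in place of chloro on an aromatic carbon and turns 2,6-dichlorophenyl into 2-chloro-6-fluorophenyl. Going by the values given here, the only measured step that bears on this is a step that the two limits leave unreadable from compound 1 to compound 2, with 2,6-dichlorophenyl in place of 2,6-difluorophenyl, and it offers no size to carry over. Compound 3 carries one halogen from each of the two measured aryl groups, so it is expected to stay low in toxicity, with only a tentative lean toward higher numbers. The expected change is a step that the limit leaves unreadable from compound 2 to compound 3, and this estimate is loose. For compound 3 the estimated value is 30000 nM, with an expected range from 10000 nM to 90000 nM, and the assay may again report only a limit.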

Compound 3, half-maximal cytotoxic concentration: > 13000 nM
Compound 3 was reported as a limit; the forecaster's own chance of this, stated with the estimate: 65%; the middle value lies beyond the limit too.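

In this assay compound 3 gives > 13000 nM, which is a limit and not a number. Going by these compounds alone, with only limits for compound 1, compound 2 and compound 3, no step among them can be read. The compounds shown leave open where each one sits on the scale, and whether exchanging chloro and fluoro changes the read-out at all.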